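This account rests on a few compounds, and the source may have more. Where it says the series, first, only, none or still open, it means among the compounds named here.

Measured compounds:

- compound 1, `COc1ccc(C2CC(c3ccc(Cl)cc3)=NN2c2nc(-c3ccccc3)c(C#N)c(=O)n2C)cc1`: 6070 nM
- compound 2, `Cn1c(N2N=C(c3ccccc3)CC2c2ccccc2)nc(-c2ccc(Cl)cc2)c(C#N)c1=O`: 28100 nM
- compound 3, `COc1ccc(C2CC(c3ccccc3)=NN2c2nc(-c3ccc(Cl)cc3)c(C#N)c(=O)n2C)cc1`: 23800 nM

All three were tested in a functional assay on A549 cells (Homo sapiens) for antiproliferative activity, with a stated time of 72 h; a lower number here means a stronger inhibitor, a higher number a weaker inhibitor. Compound 3 gives 23800 nM, the second highest of the three numbers; its nearest neighbour is compound 2, whose value lies within the scatter, while compound 1 sits a good deal lower, beyond the scatter.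

Compound 4, `COc1ccc(C2CC(c3ccc(Cl)cc3)=NN2c2nc(-c3ccc(Cl)cc3)c(C#N)c(=O)n2C)cc1`, is not yet measured. It differs from compound 3 in one place: chloro in place of hydrogen on an aromatic carbon. Within the data shown here, the only measured single step, a 1.2-fold lower number from compound 2 to compound 3 (0.07 log units; within the scatter), concerns a methoxy group, not a chloro, so it says nothing direct about the change at hand. Compound 1 and compound 3 also differ, but in two places at once, so their values only show that placing the chloro on the pyrazoline-bound ring rather than on the core-bound ring goes with a lower number. Among the measured compounds shown here, no measured step speaks to adding a second chloro, so a modest step in either direction is as plausible as none beyond the scatter.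

The expected result for compound 4 in this assay is 14000 nM, with a range from 4000 nM to 45000 nM; this expectation corresponds to a step of a 1.7-fold lower number from compound 3 to compound 4 (0.23 log units; within the scatter).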

Compound 4, half-maximal inhibitory concentration: 35700 nM
Compound 4: the middle estimate sits 2.6-fold (0.41 log units) below what was measured; measured number inside the range.
By their numbers in this assay, from the lowest: compound 1; then compounds 3, 2 and 4 (each within the scatter of the next).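

In this assay the change from phenyl to 4-chlorophenyl on the plain phenyl ring of compound 3 gives a 1.5-fold higher number from compound 3 to compound 4 (0.18 log units; within the scatter) and so has no effect that can be told apart from assay noise at this place. The same change on the plain phenyl ring of compound 1, which sits at a different place on the molecule, gives a 5.9-fold higher number from compound 1 to compound 4 (0.77 log units; beyond the scatter) and does go beyond the scatter, so in this pair of steps the outcome of adding a chloro depends on which ring receives it. Nothing available explains why the two places differ.

These are single steps, and both end at compound 4, so they leave open whether the difference between the two places would hold in compounds without the methoxy group or without the chloro already on the other ring. They also leave open how a fluoro atom, a methyl group or an amine would compare with chloro at either place.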